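Shortening the Chain of Compound 1

A few compounds are considered here, and "the series" means these few. Any claim that something is new, unique, unknown or untested is made for them only; others in the source may bear on it.

In a functional assay on SK-HEP1 cells (Homo sapiens) for inhibition, read by MTT assay, with a stated time of 72 h (on this read-out lower numbers stand for stronger inhibition and higher numbers for weaker inhibition), compound 1 `Nc1nc2cc(-c3nn(CCCCCCCCCC(=O)NO)c4ncnc(N)c34)ccc2o1` gives 14100 nM and compound 2 `Nc1ncnc2c1c(-c1cnc3[nH]ccc3c1)nn2CCCCCCCCCC(=O)NO` gives 23500 nM, so the two stand within the usual scatter of each other. Compound 3 `Nc1nc2cc(-c3nn(CCCCCC(=O)NO)c4ncnc(N)c34)ccc2o1` keeps the core of compound 1 and alters only the chain: hydroxycarbamoyl in place of 4-(hydroxycarbamoyl)butyl on a saturated chain carbon, five bonds along the chain from an aromatic nitrogen, on a saturated chain carbon, five bonds along the chain from an aromatic nitrogen. Within the data shown here, the only measured step, a 1.7-fold higher number from compound 1 to compound 2 (0.22 log units; within the scatter), exchanges an aromatic ring group and leaves the chain untouched. Among the measured compounds shown here, it therefore bears only indirectly on this change, and no measured pair shows what altering the chain does. A lower number is only a tentative expectation, so the estimated change is a 2.8-fold lower number from compound 1 to compound 3 (0.45 log units; beyond the scatter) in this assay, with much uncertainty. For compound 3 the expected value is 5000 nM, with an estimated range from 700 nM to 25000 nM.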

Compound 3, half-maximal inhibitory concentration: 3080 nM
Beside the measured number, compound 3's estimate is 1.6-fold (0.21 log units) above it, and the stated range covers the measured number.
By their numbers in this assay, from the lowest: compound 3; then compounds 1 and 2 (each within the scatter of the next).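

Cutting 4-(hydroxycarbamoyl)butyl back to hydroxycarbamoyl at this place on the chain gives, in this assay, a 4.6-fold lower number from compound 1 to compound 3 (0.66 log units; beyond the scatter). This is the first step among these compounds that lies beyond the scatter, and it comes from the chain alone, with the core of compound 1 unchanged, so the length of the chain ending in the hydroxycarbamoyl group does affect this read-out. Nothing available here accounts for the size or direction of this step.

Two chain lengths on one core show a difference but not a trend, so a longer chain or one of intermediate length could fall anywhere relative to them. On these data alone, it also stays open whether the hydroxycarbamoyl end itself matters, which a carboxylic acid in its place would test, and whether the same shortening would act alike on the core of compound 2.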